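Compound 4: An Estimate Built on Limits

The compounds below may be only part of what the source reports. "The series", "measured", "known", "first", "only" and "open" are said of these compounds alone.

Compound 1 `Cc1c2c(n3c1CCCNC[C@H](C)Nc1cc-3ccc1C(N)=O)CC(C)(C)CC2=O`: > 0.5 h
Compound 2 `CC[C@H](N)C(=O)N1CCc2c(C)c3c(n2-c2ccc(C(N)=O)c(c2)N[C@@H](C)[C@H](C)C1)CC(C)(C)CC3=O`: > 0.5 h
Compound 3 `Cc1c2c(n3c1CCN(C(=O)C1(N)CC1)C[C@@H](C)[C@H](C)Nc1cc-3ccc1C(N)=O)CC(C)(C)CC2=O`: > 0.5 h

In an in vitro ADME assay on microsomes (Rattus norvegicus) for metabolic stability (a higher number here means that the compound lasts longer, a lower number that the compound disappears faster), compound 2 gives > 0.5 h, which is a limit of the assay and not a number. Compound 2 therefore has no exact place among the other compounds, and the whole record amounts to the limit of > 0.5 h in this assay, at which 3 of the 3 values shown sit.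

Compound 4 `Cc1c2c(n3c1CCN(C(=O)[C@H](C)O)C[C@@H](C)[C@H](C)Nc1cc-3ccc1C(N)=O)CC(C)(C)CC2=O` has 1-hydroxyethyl in place of 1-aminopropyl on a carbonyl carbon, and otherwise matches compound 2. The counted change is 1-hydroxyethyl in place of 1-aminopropyl on a carbonyl carbon.

Going by the values given here, only one measured step touches this place: 1-aminocyclopropyl in place of 1-aminopropyl on a carbonyl carbon, which is a step that the two limits leave unreadable from compound 2 to compound 3. That step offers no size to carry over, so no change beyond the usual scatter is expected in this assay, and no direction can be given. The expected step is a step that the limit leaves unreadable from compound 2 to compound 4, an estimate that carries wide uncertainty.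

Compound 4 is expected to give about 0.7 h, with an estimated range from 0.35 h to 1.5 h. A report as a limit, rather than a number, is the likeliest expected outcome.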

Compound 4, half-life: 0.483 h
The estimate for compound 4 lay 1.4-fold (0.16 log units) above the measured number, and the stated range covers the measured number.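

In this assay, compound 4 is the only compound shown that gives a number rather than a limit, so this place on the carbonyl carbon now has one readable value. Replacing the amine-bearing group with 1-hydroxyethyl gives an at least 1.0-fold lower number from compound 2 to compound 4 (0.01 log units; that floor lies within the scatter), and the same comparison with the cyclopropyl partner gives an at least 1.0-fold lower number from compound 3 to compound 4 (0.01 log units; that floor lies within the scatter), so neither step can be called a real loss of stability. The step among the compounds that sit at the limit cannot be read, and the true size of both steps above stays unknown, as most of the record still rests on a single limit: the limit of > 0.5 h in this assay, at which 3 of the 4 values shown sit.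

The change from 1-aminopropyl to 1-hydroxyethyl swaps nitrogen for oxygen and also alters the chain, and the compounds shown cannot separate the two; 1-aminoethyl on the same carbonyl carbon would do that. From the compounds shown here alone, it also remains open how a group with neither an amine nor a hydroxyl, such as a plain ethyl, would behave at this place.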